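An Ester Swap at the Assay Limit

The source may hold more compounds than are shown below. What is called first, only, known or untested is meant among the compounds shown, and "the series" means these compounds.

Values in a toxicity assay on HEK-293T cells (Homo sapiens) for cytotoxicity, read by MTT assay, with a stated time of 48 h (a higher number here means a weaker inhibitor, a lower number a stronger inhibitor), for the measured compounds:
- compound 1 `C=C1[C@H](O)[C@@H](O)[C@@H](O)C(C)(C)/C=C/[C@H](C)[C@H](OC(=O)c2ccccc2)[C@@]2(O)C[C@@](C)(O)[C@H](OC(C)=O)[C@@H]2[C@H]1OCC(C)C` gives > 100000 nM (a limit of the assay)
- compound 2 `C=C1[C@H](OC(C)=O)[C@@H](OC(C)=O)[C@@H](OC(C)=O)C(C)(C)/C=C/[C@H](C)[C@H]2O[C@]3(C)C[C@@]2(OC(=O)c2ccccc2)[C@H]([C@H]3OC(C)=O)[C@H]1OCC(C)C` gives 13500 nM (a number)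
- compound 3 `C=C1[C@H](OC(C)=O)[C@@H](OC(=O)c2cccc(C)c2)[C@@H](OC(C)=O)C(C)(C)/C=C/[C@H](C)[C@H]2O[C@]3(C)C[C@@]2(OC(=O)c2ccccc2)[C@H]([C@H]3OC(C)=O)[C@H]1OCC(C)C` gives > 100000 nM (a limit of the assay)

Compound 3 has only a limit (> 100000 nM) and no number. It shares that position with compound 1 (the limit of > 100000 nM in this assay, at which 2 of the 3 values shown sit).

Compound 4 `C=C1[C@H](OC(C)=O)[C@@H](OC(=O)C(C)(C)C)[C@@H](OC(C)=O)C(C)(C)/C=C/[C@H](C)[C@H]2O[C@]3(C)C[C@@]2(OC(=O)c2ccccc2)[C@H]([C@H]3OC(C)=O)[C@H]1OCC(C)C` has not yet been measured. It carries tert-butyl in place of 3-methylphenyl on a carbonyl carbon.

One measured step changed this same carbonyl carbon, placing 3-methylphenyl where methyl had been (an at least 7.4-fold higher number from compound 2 to compound 3 (0.86 log units; beyond the scatter)). As far as these compounds go, that step lies beyond the scatter, and its full size is unknown. Tert-butyl is neither of those two groups, so compound 4 is expected to fall between compound 3 and compound 2 (13500 nM). A modest move to a lower number in this assay is therefore expected (an at least 1.6-fold lower number from compound 3 to compound 4 (0.22 log units; that floor lies within the scatter)), though a second limit is just as likely. Compound 4 is estimated at 60000 nM (range 15000 nM to 150000 nM).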

Compound 4, half-maximal inhibitory concentration: > 100000 nM
Compound 4 was reported as a limit; the forecaster's own chance of this, stated with the estimate: 50%; middle value at least 1.6-fold (0.22 log units) away from the limit.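

Placing tert-butyl where methyl had been on this carbonyl carbon gives an at least 7.4-fold higher number from compound 2 to compound 4 (0.86 log units; beyond the scatter) in this assay. The earlier step to compound 3 involved 3-methylphenyl, which has an aromatic ring, whereas tert-butyl has no ring, so among these compounds a ring in the new group is not needed for the number to rise from that of compound 2. The step between compound 3 and compound 4 cannot be read, so these two groups cannot be ranked against each other: the limit of > 100000 nM in this assay, at which 3 of the 4 values shown sit.

As far as these compounds go, the true values of compound 3 and compound 4 remain unknown, and so does the full size of each change away from methyl. Also open, from the compounds shown here alone, is whether a small group only slightly larger than methyl, such as ethyl, or a chain ending in an amine, would keep a measurable number in this assay.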